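The source may report more compounds than this note shows. Statements on the series, on what has been measured and on what is new or still open speak of the compounds shown alone.

Three compounds built on a shared core were examined in a functional assay on SMMC-7721 cells (Homo sapiens) for cytotoxicity, read by MTT assay, with a stated time of 4 days; on this read-out lower numbers stand for stronger inhibition and higher numbers for weaker inhibition. Compound 2 `C=C1C[C@]23C[C@@]1(O)CC[C@@H]2c1cccc(C)c1[C@@H]3Cn1cc(-c2ccc(C)cc2)nn1` carries a 4-methylphenyl group. In this assay compound 2 gives only a limit of the assay, > 20000 nM, so no number is known for it. Compound 1 `C=C1C[C@]23C[C@@]1(O)CC[C@H]2c1ccc(OS(=O)(=O)c2ccc(C)cc2)c(C)c1[C@@H]3Cn1cc(-c2ccc(Br)cc2)nn1` likewise gives only a limit, > 20000 nM. Compound 3 `COc1ccc(-c2cn(C[C@H]3c4c(ccc(O)c4C)[C@@H]4CC[C@@]5(C)C[C@]43CC5=O)nn2)cc1` also gives only a limit, > 20000 nM. Where compound 2 stands is therefore told only by the edge of the measurable range: the limit of > 20000 nM in this assay, at which 3 of the 3 values shown sit. Among the compounds with values here, no step between two measured compounds can be worked out here, since none of the three carries a number.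

Compound 4 `C=C1C[C@]23C[C@@]1(O)CC[C@@H]2c1cccc(C)c1[C@@H]3Cn1cc(-c2ccc(Br)cc2)nn1` has not yet been measured. It differs from compound 2 in one place: bromo in place of methyl on an aromatic carbon The 4-methylphenyl group thus becomes a 4-bromophenyl group, and the rest of the molecule stays as in compound 2. Compound 1, which also carries a 4-bromophenyl group, shows only the limit > 20000 nM. The expected step, a step that the limit leaves unreadable from compound 2 to compound 4, is none beyond the scatter. Compound 4 is expected to give about 30000 nM, within 10000 nM to 100000 nM, and most probably to be reported once more only as a limit.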

Compound 4, half-maximal inhibitory concentration: > 20000 nM
Compound 4 was reported as a limit; the forecaster's own chance of this, stated with the estimate: 80%; the middle value lies beyond the limit too.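

Within the data shown here, compound 2 and compound 4 each give a limit of the assay rather than a number, and no step between them can be read in this assay. All the compounds shown stop at the same edge: the limit of > 20000 nM in this assay, at which 4 of the 4 values shown sit. The compounds shown leave open whether 4-bromophenyl in place of 4-methylphenyl changes cytotoxicity at all, and what on the shared core would bring a value into the measurable range.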